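This account rests on a few compounds, and the source may have more. Where it says the series, first, only, none or still open, it means among the compounds named here.

Of the compounds shown here, three that share one core have been tested in an ADME assay on Vero cells (Chlorocebus sabaeus) for cytotoxicity, read by MTT assay, with a stated time of 48 h; on this read-out higher numbers stand for weaker inhibition and lower numbers for stronger inhibition. Compound 1 `O=c1nc(NCc2cccc(F)c2)oc2c([N+](=O)[O-])cc(C(F)(F)F)cc12` gives only a limit in this assay, > 64 ug/mL. Compound 2 `O=c1nc(Nc2ccccc2)oc2c([N+](=O)[O-])cc(C(F)(F)F)cc12` gives 37.9 ug/mL. Compound 3 `O=c1nc(NCc2ccccc2)oc2c([N+](=O)[O-])cc(C(F)(F)F)cc12` gives 25.4 ug/mL, the lowest of the two numbers, with compound 2 nearest; the step of a 1.5-fold lower number from compound 2 to compound 3 (0.17 log units; within the scatter) lies within the scatter, so the two cannot be told apart. The step of an at least 2.5-fold lower number from compound 1 to compound 3 (0.40 log units; beyond the scatter) is the only one beyond the scatter. It rests on (the limit of > 64 ug/mL in this assay, at which 1 of the 3 values shown sits).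

Compound 4 `CN(Cc1ccccc1)c1nc(=O)c2cc(C(F)(F)F)cc([N+](=O)[O-])c2o1` differs from compound 3 by a single change: methyl in place of hydrogen on a nitrogen on an aromatic ring. For the measured compounds named here, none of the measured steps touches that nitrogen in this way; all three swap the group attached to it, and together they move the numbers only a little, with an at least 1.6-fold lower number from compound 1 to compound 2 (0.22 log units; that floor lies within the scatter) and a 1.5-fold lower number from compound 2 to compound 3 (0.17 log units; within the scatter) not clearly beyond the scatter. No direction can therefore be read from them for a methyl in place of hydrogen. The expectation for compound 4 is a step of a 1.1-fold higher number from compound 3 to compound 4 (0.04 log units; within the scatter), which stays inside the usual scatter. Compound 4 is expected to give 28 ug/mL, with a likely range from 12 ug/mL to 64 ug/mL.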

Compound 4, half-maximal inhibitory concentration: 3.84 ug/mL
Beside the measured number, compound 4's estimate is 7.3-fold (0.86 log units) above it; measured number below the stated range.
By their numbers in this assay, from the lowest: compound 4; then compounds 3 and 2 (each within the scatter of the next). At a limit, above all of these: compound 1.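

The single methyl on this nitrogen produces a clear shift in this assay, with a 6.6-fold lower number from compound 3 to compound 4 (0.82 log units; beyond the scatter) and thus stronger inhibition. Compounds 1, 2 and 3 all keep a hydrogen on this nitrogen and differ only in the other group attached to it, so compound 4 is the first case shown in which that hydrogen is replaced, and it shows that this position responds to so small an addition. Compound 4 also stands apart from the other two relatives, with a 9.9-fold lower number from compound 2 to compound 4 (0.99 log units; beyond the scatter) and an at least 16-fold lower number from compound 1 to compound 4 (1.22 log units; beyond the scatter), and the second of these steps gives only a floor since compound 1 is known only as a limit: the limit of > 64 ug/mL in this assay, at which 1 of the 4 values shown sits.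

The compounds shown leave open whether this shift belongs to methyl itself or would also follow with an ethyl group or a longer chain on the nitrogen, or with the nitrogen tied into a ring such as piperidine. They also leave open whether the same methyl would move the number similarly on the anilino group of compound 2 or the (3-fluorobenzyl)amino group of compound 1.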